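The source may hold more compounds than are shown below. What is called first, only, known or untested is meant among the compounds shown, and "the series" means these compounds.

Working notes on the series.

Compound 1 `CCCCNc1nc(N)nc2c1CNCC2` is the parent with an unsubstituted ring amine. In an assay on HEK293 cells for agonist activity at Toll-like receptor 8 (Homo sapiens), read by a luciferase reporter, with a stated time of 6 h (a higher number here means that more compound is needed for the effect, a lower number that less compound is needed), compound 1 gives 7.2 uM, the highest number among the three measured compounds. Compound 2 `CCCCNc1nc(N)nc2c1CCN(C(=O)c1ccccc1)C2` carries a benzoyl group on a ring nitrogen and in this assay compound 2 gives 0.8 uM, a lower number than compound 1 shows. Compound 3 `CCCCNc1nc(N)nc2c1CN(Cc1c[nH]c3ccccc13)CC2` carries an indolylmethyl group on a ring nitrogen and in this assay compound 3 gives 0.22 uM, the lowest number of the three. Going by the values given here, no two of the measured compounds differ in one place only, so no single step is isolated here; what the values show is that both substituted ring amines sit well below the parent.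

Compound 4 `CCCCNc1nc(N)nc2c1CN(C(=O)c1cnccn1)CC2` is the next compound to be run in this assay. It differs from compound 1 as follows: (pyrazin-2-yl)carbonyl in place of hydrogen on an amine nitrogen in a ring. This is an acyl group on the ring nitrogen, as in compound 2, with an aromatic ring that holds two hetero atoms instead of none. Given that compound 2 gives 0.8 uM against compound 1 at 7.2 uM, a step of comparable size is expected for compound 4, in the direction of a lower number and beyond the scatter, namely a 7.2-fold lower number from compound 1 to compound 4 (0.86 log units; beyond the scatter). Compound 4 is therefore expected to give about 1 uM in this assay, within a range of 0.3 uM to 3 uM.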

Compound 4, minimum effective concentration: 2.2 uM
Compound 4: the middle estimate sits 2.2-fold (0.34 log units) below what was measured, within the range that was stated.
By their numbers in this assay, from the lowest: compound 3; then compound 2; then compound 4; then compound 1.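

Going by these compounds alone, this is the first single change that can be read on its own: on the amine nitrogen in the ring, (pyrazin-2-yl)carbonyl in place of hydrogen gives a 3.3-fold lower number from compound 1 to compound 4 (0.51 log units; beyond the scatter) in this assay. An acyl group carrying a six-membered aromatic ring with 2 hetero atoms is therefore compatible with a lower number at this nitrogen, although the step is only modest, even while lying beyond the scatter. Nothing available explains the size of this step.

Open, from the compounds shown here alone, is what the acyl link and the aromatic ring each contribute on this nitrogen, since compound 2 carries its benzoyl group on a core arranged differently from that of compound 4, and so cannot be set directly beside it. Within the data shown here, also open is where a plain benzoyl, an acetyl or a pyridine-2-carbonyl group on the same nitrogen would fall, and whether a methylene-linked group such as the one in compound 3, which gives 0.22 uM in this assay, would keep that low number with a pyrazin-2-yl ring in place of the indolyl ring.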